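This account rests on a few compounds, and the source may have more. Where it says the series, first, only, none or still open, it means among the compounds named here.

Measured compounds:
- compound 1 `CCn1c(-c2cnc(C)nc2)nc2c(N[C@H]3CCN(C(=O)C4CCC4)C3)ncnc21`: 0.6 h
- compound 2 `CCn1c(-c2cnc(C)nc2)nc2c(N[C@H]3CCN(C(=O)N4CC(OC)C4)C3)ncnc21`: 4 h

Among the compounds with values here, in an ADME assay (Rattus norvegicus, strain Wistar Han) for metabolic stability (on this read-out lower numbers stand for a shorter-lived compound and higher numbers for a longer-lived compound), compound 2 gives the higher of the two numbers, and the only neighbour, compound 1, gives 0.6 h. Within the data shown here, the single step in the set, a 6.7-fold higher number from compound 1 to compound 2 (0.82 log units; beyond the scatter), is the one that separates them.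

Compound 3 `CCn1c(-c2cnc(C)nc2)nc2c(N[C@H]3CCN(C(=O)C4CC4)C3)ncnc21` is the next compound to be measured. It differs from compound 2 by cyclopropyl in place of 3-methoxyazetidin-1-yl on a carbonyl carbon. Among the measured compounds shown here, the only measured step that bears on this change is a 6.7-fold higher number from compound 1 to compound 2 (0.82 log units; beyond the scatter), which exchanged a carbocycle on the same carbonyl carbon for the 3-methoxyazetidin-1-yl group; compound 3 goes the other way, from that group back to a carbocycle, here cyclopropyl. The expectation in this assay is therefore a drop of about the size seen in that step, a 5.0-fold lower number from compound 2 to compound 3 (0.70 log units; beyond the scatter), landing near the number for compound 1.

Compound 3 is estimated at 0.8 h, with a range from 0.3 h to 2.5 h.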

Compound 3, half-life: 2.7 h
Beside the measured number, compound 3's estimate is 3.4-fold (0.53 log units) below it; measured number above the stated range.
By their numbers in this assay, from the lowest: compound 1; then compounds 3 and 2 (each within the scatter of the next).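

With a 1.5-fold lower number from compound 2 to compound 3 (0.17 log units; within the scatter) in this assay, 3-methoxyazetidin-1-yl and cyclopropyl on this carbonyl carbon cannot be told apart, so among these compounds the nitrogen and oxygen of the leaving group are not needed for a number of this size. Within the data shown here, the carbocycles themselves do differ: a 4.5-fold higher number from compound 1 to compound 3 (0.65 log units; beyond the scatter) marks cyclobutyl as the one group of the three that stands apart at this place. No measurement here accounts for the difference between the two carbocycles.

Going by these compounds, it remains open whether cyclobutyl is a single exception or whether a larger ring such as cyclopentyl, or an open chain such as isopropyl, would read like it. Also open, on these data alone, is how azetidin-1-yl without the methoxy, or pyrrolidin-1-yl, on the same carbonyl carbon would compare in this assay.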